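Ethoxyethyl versus methoxyethyl on the shared aminopyridopyrimidine-type core

The source may report more compounds than this note shows. Statements on the series, on what has been measured and on what is new or still open speak of the compounds shown alone.

Measured in a functional assay (Nicotiana tabacum); a lower number here means a stronger inhibitor, a higher number a weaker inhibitor:
Compound 1, `CCCCCCNc1nc(SC)nc2ncccc12`: 3330 nM
Compound 2, `CCCCCCCNc1nc(SC)nc2ncccc12`: 4070 nM
Compound 3, `COCCNc1nc(SC)nc2ncccc12`: 2530 nM

Compound 1 and compound 2 differ by methyl in place of hydrogen on a saturated chain carbon, six bonds along the chain from a nitrogen on an aromatic ring; the step is a 1.2-fold higher number from compound 1 to compound 2 (0.09 log units; within the scatter). Compound 3 differs from compound 1 by methoxy in place of butyl on a saturated chain carbon, two bonds along the chain from a nitrogen on an aromatic ring, and the step is a 1.3-fold lower number from compound 1 to compound 3 (0.12 log units; within the scatter). The remaining pair gives a 1.6-fold lower number from compound 2 to compound 3 (0.21 log units; within the scatter). All three values thus sit within the scatter of one another, and no ordering among them is claimed.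

Not yet measured is compound 4, `CCOCCNc1nc(SC)nc2ncccc12`. It differs from compound 3 by methyl in place of hydrogen on a saturated chain carbon bound to an oxygen on a saturated carbon. Among the measured compounds shown here, this is the same kind of change as the one from compound 1 to compound 2, but not the same: there the carbon lies six bonds along the chain from a nitrogen on an aromatic ring, whereas here it is bound to an oxygen on a saturated carbon. The cores differ as told by methoxy in place of butyl on a saturated chain carbon, two bonds along the chain from a nitrogen on an aromatic ring.

The step in this assay is expected to be a 1.1-fold higher number from compound 3 to compound 4 (0.06 log units; within the scatter), resting on the earlier 1.2-fold higher number from compound 1 to compound 2 (0.09 log units; within the scatter), which was within the scatter. Compound 4 is therefore estimated at 2900 nM, with a range from 1400 nM to 6000 nM.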

Compound 4, half-maximal inhibitory concentration: 7590 nM
Compound 4: middle estimate off by 2.6-fold (0.42 log units), on the low side; measured number outside the range, above it.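

In this assay, methyl in place of hydrogen on the saturated chain carbon bound to an oxygen gives a 3.0-fold higher number from compound 3 to compound 4 (0.48 log units; beyond the scatter), yet set beside the same kind of change on the core of compound 1, the two steps cannot be told apart: the same change on two cores in this assay, a 1.2-fold higher number (0.09 log units; within the scatter) from compound 1 to compound 2 and a 3.0-fold higher number (0.48 log units; beyond the scatter) from compound 3 to compound 4, 2.5-fold (0.39 log units) apart, within the scatter of two such steps. With one pair on each core, and the change at a different place on each chain, the data show neither that the step carries over at a fixed size nor that it depends on the core. Against the plain alkyl chains the readings are a 2.3-fold higher number from compound 1 to compound 4 (0.36 log units; beyond the scatter) and a 1.9-fold higher number from compound 2 to compound 4 (0.27 log units; within the scatter); only the first lies beyond the scatter, so the ether chains and the alkyl chains form no clear order.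

Open, from the compounds shown here alone, is whether a propoxy group in place of the ethoxy would continue the higher numbers or fall back towards the methoxy value. Also open, going by these compounds, is how an amine or a carboxylic acid in place of the ether would read on this core.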